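From phenyl to 3-hydroxyphenyl

This account rests on a few compounds, and the source may have more. Where it says the series, first, only, none or still open, it means among the compounds named here.

In a functional assay on A549 cells (Homo sapiens) for inhibition, read by MTT assay, with a stated time of 24 h (on this read-out lower numbers stand for stronger inhibition and higher numbers for weaker inhibition), compound 1 (`CC1(C)[C@H]2CC[C@]1(C)N(Cc1cn(-c3ccc(F)cc3)nn1)C(=O)C2`) gives 230 nM as its reading, compound 2 (`CC1(C)[C@H]2CC[C@]1(C)N(Cc1cn(-c3ccc(O)cc3)nn1)C(=O)C2`) gives 140 nM and compound 3 (`CC1(C)[C@H]2CC[C@]1(C)N(Cc1cn(-c3ccccc3)nn1)C(=O)C2`) gives 70 nM on the same read-out. Compound 3 stands within the scatter of compound 2 (a 2.0-fold lower number from compound 2 to compound 3 (0.30 log units; within the scatter)) yet apart from compound 1 (a 3.3-fold lower number from compound 1 to compound 3 (0.52 log units; beyond the scatter)) on these numbers. Compound 4 (`CC1(C)[C@H]2CC[C@]1(C)N(Cc1cn(-c3cccc(O)c3)nn1)C(=O)C2`) takes hydroxy in place of hydrogen on an aromatic carbon, meta to a large group (hydroxy in place of hydrogen on an aromatic carbon). Among the compounds with values here, the one measured exchange of hydroxy and hydrogen runs the other way (a 2.0-fold lower number from compound 2 to compound 3 (0.30 log units; within the scatter)) and stays within the scatter, so only a small move to a higher number is expected in this assay for this change. The step expected is a 1.7-fold higher number from compound 3 to compound 4 (0.23 log units; within the scatter) on this estimate. Compound 4 is estimated at 120 nM with an expected range of 50 nM to 300 nM when measured.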

Compound 4, half-maximal inhibitory concentration: 180 nM
The estimate for compound 4 lay 1.5-fold (0.18 log units) below the measured number; the measured number falls inside the stated range.
By their numbers in this assay, from the lowest: compounds 3, 2, 4 and 1 (each within the scatter of the next, the first and the last beyond it).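

In this assay hydroxy placed on the aromatic carbon meta to a large group gives a step beyond the scatter (a 2.6-fold higher number from compound 3 to compound 4 (0.41 log units; beyond the scatter)), whereas the earlier exchange of hydroxy and hydrogen stayed within it. The two hydroxyphenyl placements cannot be told apart (a 1.3-fold higher number from compound 2 to compound 4 (0.11 log units; within the scatter)), and the 3-hydroxyphenyl and 4-fluorophenyl compounds also remain within the scatter of each other (a 1.3-fold lower number from compound 1 to compound 4 (0.11 log units; within the scatter)). No evidence at hand accounts for these readings. From the compounds shown here alone, whether an amine, a carboxylic acid or a methoxy group at this place would read differently stays open.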